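This account rests on a few compounds, and the source may have more. Where it says the series, first, only, none or still open, it means among the compounds named here.

Measured compounds and their values in the cytotoxicity assay:

Compound 1 `O=C(CCCCC1CCSS1)NCc1cn(CCCOc2ccc3cc(-c4ccc(Cl)c(Cl)c4)c(=O)oc3c2)nn1`: 54.8%
Compound 2 `COc1ccc(-c2cc3ccc(OCCCCn4cc(CNC(=O)CCCCC5CCSS5)nn4)cc3oc2=O)cc1`: 55.3%
Compound 3 `O=C(CCCCC1CCSS1)NCc1cn(CCCCCOc2ccc3ccc(=O)oc3c2)nn1`: 84.9%

In a functional assay on PC-12 cells (Rattus norvegicus) for cytotoxicity, read by MTT assay, with stated times of 3 h and 2 h, tested at 50 uM (a higher number here means a stronger effect of the compound at the concentration tested, a lower number a weaker effect), compound 3 gives 84.9%, the highest of the three numbers. Compound 2 gives 55.3%, a number lower than compound 3 by more than the usual scatter. Compound 1 gives 54.8%, also lower than compound 3 by more than the scatter. Among the measured compounds shown here, none of these three pairs differs in a single place, so no step from a single structural change can be read from them.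

Compound 4 `Cc1cc(=O)oc2cc(OCCCCCn3cc(CNC(=O)CCCCC4CCSS4)nn3)ccc12` differs from compound 3 in one place: methyl in place of hydrogen on an aromatic carbon. This is the smallest kind of change, a single carbon added to the shared core, and nothing in the measured compounds shows what such a change does in this assay. The expectation is therefore a step from compound 3 to compound 4 of a number 4.9 percentage points lower from compound 3 to compound 4 (within the scatter), that is, a change not beyond the scatter, with the estimate staying close to compound 3. On that basis compound 4 is expected to give about 80% in this assay, with a likely range from 62% to 95%.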

Compound 4, a percentage reported as activity, at one concentration (the size of the read-out at that concentration, not a potency): 73.7%
Beside the measured number, compound 4's estimate is 6.3 percentage points above it, within the range that was stated.
By their numbers in this assay, from the lowest: compounds 1 and 2 (each within the scatter of the next); then compound 4; then compound 3.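

Within this assay the swap of methyl in place of hydrogen on an aromatic carbon, opposite the ring oxygen, gives a number 11.2 percentage points lower from compound 3 to compound 4 (beyond the scatter) and so provides the only step in this set that can be read from a single change. Among the compounds shown here, it shows that this position is not indifferent in this assay: a single added carbon, with no ring, no charge and no hydrogen-bond donor or acceptor, is enough to move the number past the usual scatter, something the earlier compounds, which differ in several places at once, could not show. The data offer nothing that explains why the number moves with this change.

One step at one position also leaves the shape of the trend open: an ethyl group, a chlorine atom, a methoxy group or an amine at the same carbon could continue this step, reverse it or leave the number unchanged. On these data alone, it also remains open whether methyl has a step of similar size on the same core when the chain that links the core to the rest of the molecule is shorter or longer than in compound 4.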